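From piperidinylpropyl to imidazolylethyl side chain

The source may report more compounds than this note shows. Statements on the series, on what has been measured and on what is new or still open speak of the compounds shown alone.

Measured in a functional assay on SMMC-7721 cells (Homo sapiens) for antiproliferative activity, read by MTT assay, with a stated time of 48 h; on this read-out lower numbers stand for stronger inhibition and higher numbers for weaker inhibition:
- Compound 1 `Cn1cc(C2=C(c3nn(CCCn4cncn4)c4ncccc34)C(=O)NC2=O)c2ccccc21` gives > 100000 nM as a limit
- Compound 2 `CN(C)CCCn1nc(C2=C(c3cn(C)c4ccccc34)C(=O)NC2=O)c2cccnc21` gives > 100000 nM as a limit
- Compound 3 `Cn1cc(C2=C(c3nn(CCCN4CCCCC4)c4ncccc34)C(=O)NC2=O)c2ccccc21` gives 7670 nM as a number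

In this assay, for the measured compounds named here, compound 3 gives 7670 nM as the only actual number in the set. The other two readings are limits: the limit of > 100000 nM in this assay, at which 2 of the 3 values shown sit.

Compound 4 `Cn1cc(C2=C(c3nn(CCn4ccnc4)c4ncccc34)C(=O)NC2=O)c2ccccc21` changes the side chain of compound 3 from 3-(piperidin-1-yl)propyl to 2-(1H-imidazol-1-yl)ethyl: 1H-imidazol-1-yl in place of (piperidin-1-yl)methyl on a saturated chain carbon, two bonds along the chain from an aromatic nitrogen.

Going by the values given here, two measured steps bear on this change, both large and beyond the scatter: an at least 13-fold lower number from compound 1 to compound 3 (1.11 log units; beyond the scatter) and an at least 13-fold lower number from compound 2 to compound 3 (1.11 log units; beyond the scatter). The remaining step gives no size: a step that the two limits leave unreadable from compound 1 to compound 2. Among the compounds with values here, no measured step changes the chain length. Compound 1 carries 1H-1,2,4-triazol-1-yl on its chain and is the nearest match to compound 4, so an at least 13-fold lower number from compound 1 to compound 3 (1.11 log units; beyond the scatter) is the main guide, read in reverse. A clear move to a higher number, meaning weaker inhibition, is therefore expected. The expected size is a 5.2-fold higher number from compound 3 to compound 4 (0.72 log units; beyond the scatter). For compound 4 the estimated value is 40000 nM, with an expected range of 10000 nM to 120000 nM.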

Compound 4, half-maximal inhibitory concentration: > 100000 nM
Compound 4: a limit, no number; the forecaster's own chance of this, stated with the estimate: 45%; middle value at least 2.5-fold (0.39 log units) from the limit.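

In this assay compound 4 gives > 100000 nM, which is a limit and not a number. For the compounds shown here, its step from the piperidinylpropyl side chain is an at least 13-fold higher number from compound 3 to compound 4 (1.11 log units; beyond the scatter), so this large loss now also holds for a change that replaces 3-(piperidin-1-yl)propyl with 2-(1H-imidazol-1-yl)ethyl, whereas the earlier steps kept the propyl chain and changed only its end group. The steps from compound 2 and from compound 1 to compound 4 cannot be read, so the imidazolylethyl chain cannot be ranked against the dimethylaminopropyl or triazolylpropyl chains, and compound 3 remains the only one in the set with an actual number: the limit of > 100000 nM in this assay, at which 3 of the 4 values shown sit.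

The step from compound 3 to compound 4 changes the chain and the end group together, so it does not separate the contribution of the ethyl chain from that of the 1H-imidazol-1-yl ring. The 2-(piperidin-1-yl)ethyl and 3-(1H-imidazol-1-yl)propyl chains would separate those two changes, while a 3-(morpholin-4-yl)propyl chain would test whether the number in compound 3 depends on the piperidine ring itself.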